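The source may report more compounds than this note shows. Statements on the series, on what has been measured and on what is new or still open speak of the compounds shown alone.

Working notes on the series.

Compound 1 `CN(Cc1ccccc1)C(=O)C1CCN(C(=O)c2ccc(S(C)(=O)=O)c([N+](=O)[O-])c2)CC1` carries a benzyl group on the amide nitrogen. In an assay on isolated protein for inhibition of vitamin D3 receptor (Homo sapiens), read by fluorescence polarization (a higher number here means a weaker inhibitor, a lower number a stronger inhibitor), compound 1 gives > 60000 nM, which is a limit of the assay and not a number. Compound 2 `CN(Cc1ccccc1F)C(=O)C1CCN(C(=O)c2ccc(S(C)(=O)=O)c([N+](=O)[O-])c2)CC1` differs from compound 1 by fluoro in place of hydrogen on an aromatic carbon. In this assay compound 2 gives > 60000 nM, again a limit of the assay. The step that the two limits leave unreadable from compound 1 to compound 2 is therefore not readable, since both ends sit at the limit of > 60000 nM in this assay, at which 3 of the 3 values shown sit.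

Compound 3 `CN(Cc1ccccc1)C(=O)CNC(=O)c1ccc(S(C)(=O)=O)c([N+](=O)[O-])c1` has a different core; the difference between the core of compound 3 and the core of compound 1 is not broken down here. In this assay compound 3 gives > 60000 nM, which is a limit and not a number.

Compound 4 `CN(Cc1cccc(F)c1)C(=O)CNC(=O)c1ccc(S(C)(=O)=O)c([N+](=O)[O-])c1`, not yet measured, differs from compound 3 by fluoro in place of hydrogen on an aromatic carbon. This is the same kind of change as that from compound 1 to compound 2, but the fluoro enters meta to a large group rather than ortho to a large group. Among the compounds with values here, because every value so far sits at the limit of > 60000 nM in this assay, at which 3 of the 3 values shown sit, no readable step exists on which to rest an expectation of a measurable change, and compound 4 is expected to stay at the limit as well. The step of a number no higher from compound 3 to compound 4 (the limit leaves the size open) is accordingly estimated to be flat. Compound 4 is estimated at 60000 nM, within 20000 nM to 200000 nM, most likely reported only as a limit.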

Compound 4, half-maximal inhibitory concentration: > 60000 nM
Compound 4 ended at the assay's limit; the forecaster's own chance of this, stated with the estimate: 85%; the middle value sits exactly at the limit.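

In this assay compound 4 gives > 60000 nM, a limit and not a number. No step can be read from compound 3 to compound 4, as both ends sit at the same limit: the limit of > 60000 nM in this assay, at which 4 of the 4 values shown sit.

The compounds shown leave open whether fluoro in either position, or either core, changes inhibition at all in this assay.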